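From trifluoromethyl to methoxy: compound 1 to compound 4

The source may report more compounds than this note shows. Statements on the series, on what has been measured and on what is new or still open speak of the compounds shown alone.

Measured so far in an ADME assay on microsomes from liver (Rattus norvegicus) for metabolic stability; on this read-out higher numbers stand for a longer-lived compound and lower numbers for a shorter-lived compound
compound 1 `COc1cc(OCc2cccc(-c3ccc(C(F)(F)F)cn3)c2)c2cc(-c3cn4nc(OC)sc4n3)oc2c1` gives > 2 h (a limit of the assay, not a number)
compound 2 `CNC(=O)c1ccc(-c2nc(COc3cc(OC)cc4oc(-c5cn6nc(OC)sc6n5)cc34)cs2)cc1` gives 0.517 h
compound 3 `COc1cc(OCc2csc(-c3ccc(S(C)(=O)=O)cc3)n2)c2cc(-c3cn4nc(OC)sc4n3)oc2c1` gives 1.12 h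

Compound 1 stands at the limit of > 2 h in this assay, at which 1 of the 3 values shown sits, and so has a limit rather than a number. Compound 4 `COc1ccc(-c2cccc(COc3cc(OC)cc4oc(-c5cn6nc(OC)sc6n5)cc34)c2)nc1` differs from it by methoxy in place of trifluoromethyl on an aromatic carbon and is not yet measured. Going by the values given here, only one measured step bears on this change, and it concerns a different group: a 2.2-fold higher number from compound 2 to compound 3 (0.34 log units; beyond the scatter) is modest in size. Going by that one step, a modest move is expected in this assay here, toward a shorter-lived compound. The expected change is an at least 1.6-fold lower number from compound 1 to compound 4 (0.22 log units; that floor lies within the scatter) by this estimate. Compound 4 is estimated at 1.2 h (expected range 0.5 h to 2.8 h).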

Compound 4, half-life: 0.317 h
Compound 4: the middle estimate sits 3.8-fold (0.58 log units) above what was measured, and the stated range ends above it.
By their numbers in this assay, from the lowest: compounds 4 and 2 (each within the scatter of the next); then compound 3. At a limit, above all of these: compound 1.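

In this assay, the change from 5-(trifluoromethyl)pyridin-2-yl to 5-methoxypyridin-2-yl gives an at least 6.3-fold lower number from compound 1 to compound 4 (0.79 log units; beyond the scatter), the first step shown at this position, two atoms from the ring nitrogen. Compound 1 holds a limit and not a number, so that size is only a floor: the limit of > 2 h in this assay, at which 1 of the 4 values shown sits. Going by these compounds alone, exchanging this one group therefore moves the read-out beyond the scatter, which the earlier compounds could not show for this place.

On these data alone, the full size of the step stays open. So does what an amine or a nitrile at this place would give.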